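The source may hold more compounds than are shown below. What is called first, only, known or untested is meant among the compounds shown, and "the series" means these compounds.

Measured in a functional assay on A-375 cells (Homo sapiens) for inhibition, read by MTT assay, with a stated time of 120 h; a higher number here means a weaker inhibitor, a lower number a stronger inhibitor:
compound 1 `CC(NC(=O)/C=C/Oc1ccc(NC(=O)Nc2cc(C(F)(F)F)ccc2Cl)cc1)c1ccccc1` gives 16000 nM.
compound 2 `CNC(=O)/C(C)=C/c1ccc(NC(=O)Nc2ccc(Cl)c(C(F)(F)F)c2)cc1` gives only the limit > 50000 nM.
compound 3 `C/C(=C\c1ccc(NC(=O)Nc2ccc(Cl)c(C(F)(F)F)c2)cc1)C(=O)N1CC(C)OC(C)C1` gives only the limit > 50000 nM.

Compound 2 stands at the limit, so it has no number of its own; two of the three values sit there (the limit of > 50000 nM in this assay, at which 2 of the 3 values shown sit). Compound 4 `O=C(/C=C/c1ccc(NC(=O)Nc2ccc(Cl)c(C(F)(F)F)c2)cc1)NC1CCC1` differs from compound 2 by 2-(cyclobutylcarbamoyl)ethenyl in place of 2-(methylcarbamoyl)prop-1-en-1-yl on an aromatic carbon. Among the measured compounds shown here, the one measured step, a step that the two limits leave unreadable from compound 2 to compound 3, is unreadable between its two limits, and no other measured pair alters the amide substituent or the alkene in this way, so no measured step sizes the change. The expected step of an at least 1.2-fold lower number from compound 2 to compound 4 (0.09 log units; that floor lies within the scatter) is therefore set close to the scatter and uncertain in direction. Compound 4 is estimated at 40000 nM, with a range from 10000 nM to 150000 nM, and a limit remains a likely outcome.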

Compound 4, half-maximal inhibitory concentration: 15400 nM
For compound 4 the middle estimate is 2.6-fold (0.41 log units) above the measured one; the measured number falls inside the stated range.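

On an aromatic carbon para to a large group, 2-(cyclobutylcarbamoyl)ethenyl in place of 2-(methylcarbamoyl)prop-1-en-1-yl gives, in this assay, an at least 3.2-fold lower number from compound 2 to compound 4 (0.51 log units; beyond the scatter). Among the compounds shown here, this is the first readable step, and compound 4 has a number of its own, 15400 nM. Compound 2 remains a limit, so the step is only a floor: the limit of > 50000 nM in this assay, at which 2 of the 4 values shown sit.

The amide substituent and the alkene methyl change together, so the compounds shown do not assign the step to either. As far as these compounds go, how a cyclopentyl amide or a carboxylic acid would read in this place remains open.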